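Swapping 1-phenylethyl for methyl on an amide

The source may report more compounds than this note shows. Statements on the series, on what has been measured and on what is new or still open speak of the compounds shown alone.

Compound 1 `C/C(=C\c1ccc(NC(=O)Nc2ccc(Cl)c(C(F)(F)F)c2)cc1)C(=O)NC(C)c1ccccc1`: > 50000 nM (a limit, not a number)
Compound 2 `CC(NC(=O)C#Cc1ccc(NC(=O)Nc2cc(C(F)(F)F)ccc2Cl)cc1)c1ccccc1`: 3170 nM
Compound 3 `CC(NC(=O)c1cccc(-c2ccc(NC(=O)Nc3ccc(Cl)c(C(F)(F)F)c3)cc2)c1)c1ccccc1`: 6320 nM

All three results come from a functional assay on HT-29 cells (Homo sapiens) for inhibition, read by MTT assay, with a stated time of 120 h; on this read-out higher numbers stand for weaker inhibition and lower numbers for stronger inhibition. Compound 1 gives only a limit of the assay, > 50000 nM, and not a number. This places compound 1 at the limit of > 50000 nM in this assay, at which 1 of the 3 values shown sits. Compound 2 and compound 3 both returned true numbers, and both also carry 1-phenylethyl on an amide-type nitrogen.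

Compound 4 `CNC(=O)/C(C)=C/c1ccc(NC(=O)Nc2ccc(Cl)c(C(F)(F)F)c2)cc1` has not yet been measured. Its change from compound 1 is a single swap: methyl in place of 1-phenylethyl on an amide-type nitrogen. The rest of the structure stays the same.

For the measured compounds named here, no measured pair shows this swap on its own, so its effect can only be estimated. The starting point is also uncertain, since compound 1 has no exact value. Compound 4 is expected to stay weak, close to the limit of this assay, and it may return only a limit too. The expected change is an at least 1.6-fold lower number from compound 1 to compound 4 (0.22 log units; that floor lies within the scatter), a modest move towards stronger inhibition at best. For compound 4 the estimated value is 30000 nM, with an expected range from 8000 nM to 60000 nM.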

Compound 4, half-maximal inhibitory concentration: > 50000 nM
Compound 4 ended at the assay's limit; the forecaster's own chance of this, stated with the estimate: 50%; middle value at least 1.6-fold (0.22 log units) from the limit.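

In this assay compound 4 gives > 50000 nM, a limit and not a number. Compound 1 also gives only a limit, so no step from compound 1 to compound 4 can be read: the limit of > 50000 nM in this assay, at which 2 of the 4 values shown sit.

From the compounds shown here alone, what stays open is how far either compound lies beyond that limit, and whether methyl in place of 1-phenylethyl changes inhibition at all.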